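The compounds below may be only part of what the source reports. "The series", "measured", "known", "first", "only" and "open" are said of these compounds alone.

Working notes on the series. Among the compounds with values here, compound 2 `CCN(CC)C(=O)c1cc(-c2ccc(F)cc2F)ccc1OC(=O)c1ccccc1` is one of two compounds measured so far in a functional assay on the whole organism (Ear) for inhibition, with Mus musculus as the target, at a dose of 40 mg/kg by the oral route (on this read-out higher numbers stand for more inhibition at the one dose given (going by the name of the read-out) and lower numbers for less inhibition), where compound 2 gives 65.2%. Its nearest neighbour is compound 1 `CNC(=O)c1cc(-c2ccc(F)cc2F)ccc1OC(=O)c1ccccc1`, which in this assay gives 68.9%; the step of a number 3.7 percentage points lower from compound 1 to compound 2 (within the scatter) lies within the scatter, so the two numbers cannot be ordered against each other.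

Compound 3 `CN1CCN(NC(=O)c2cc(-c3ccc(F)cc3F)ccc2OC(=O)c2ccccc2)CC1` is not yet measured. It differs from compound 2 by (4-methylpiperazin-1-yl)amino in place of diethylamino on a carbonyl carbon. Within the data shown here, the only measured step at the same place is a number 3.7 percentage points lower from compound 1 to compound 2 (within the scatter), which exchanged one amino group on the carbonyl carbon for another and gave no change beyond the scatter. Among the measured compounds shown here, the present change is of a different kind, since the group that enters brings a six-membered non-aromatic ring, one hydrogen-bond donor and two hydrogen-bond acceptors, none of which the earlier step tested; the single step available is therefore only weak guidance.

On that basis compound 3 is expected to give about 62%, with a plausible range from 40% to 80%, so that the estimated step of a number 3.2 percentage points lower from compound 2 to compound 3 (within the scatter) stays within the scatter, with the range widened to allow for the untested ring.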

Compound 3, a percentage reported as inhibition, in the whole organism at one dose (the size of the read-out at that dose, not a potency): 27.5%
Compound 3: middle estimate off by 34.5 percentage points, on the high side; the whole stated range lies above it.
By their numbers in this assay, from the lowest: compound 3; then compounds 2 and 1 (each within the scatter of the next).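

In this assay the place on the carbonyl carbon proves sensitive to the group it carries, which the earlier step within the scatter did not show: (4-methylpiperazin-1-yl)amino in place of diethylamino gives a large fall (a number 37.7 percentage points lower from compound 2 to compound 3 (beyond the scatter)), and 4-methylpiperazin-1-yl in place of methyl on the amide-type nitrogen gives another (a number 41.4 percentage points lower from compound 1 to compound 3 (beyond the scatter)). Both steps end at the only compound shown with a six-membered non-aromatic ring in this group, and that group also differs from diethylamino in its count of hydrogen-bond donors and acceptors, so the change does not separate these features from one another. Nothing at hand bears on the reason for the fall.

The compounds shown leave open whether the lower number goes with the ring as a whole, with its second ring nitrogen or with its methyl group, a question that a piperidin-1-yl, a morpholin-4-yl or an unsubstituted piperazin-1-yl group on the amide-type nitrogen could address. They also leave open whether an open-chain amine such as 2-(dimethylamino)ethyl at that nitrogen goes with a similar fall.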